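The source may hold more compounds than are shown below. What is called first, only, known or untested is meant among the compounds shown, and "the series" means these compounds.

Compound 1, `Cc1ccc(C23CCC(=O)N2CCCO3)c(C)c1`, gives in a functional assay on the whole organism with Mus musculus as the target, in the maximal electroshock model (on this read-out lower numbers stand for an effect already at smaller amounts and higher numbers for an effect only at larger amounts of compound), a value of > 150 mg/kg, which is a limit of the assay and not a number.
Compound 2, `COc1ccc(C(=O)CCC(=O)NCCCO)cc1`, gives in this assay > 600 mg/kg, likewise a limit.
Compound 3, `O=C(CCC(=O)c1cccs1)NCCCO`, gives in this assay > 300 mg/kg, again a limit.

None of the three measured compounds has a proper number in this assay; each stopped at a limit. Compound 2 stands at the limit of > 600 mg/kg in this assay, at which 1 of the 3 values shown sits, the highest of the three limits, and nothing more than that can be said about where it lies relative to compound 1 at the limit of > 150 mg/kg in this assay, at which 1 of the 3 values shown sits, or compound 3 at the limit of > 300 mg/kg in this assay, at which 1 of the 3 values shown sits, since none of these values is a true dose.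

The step from compound 2 to compound 4, `O=C(CCC(=O)c1ccc(Cl)cc1)NCCCO`, changes one place: chloro in place of methoxy on an aromatic carbon. The rest of the molecule, including the chain ending in the alcohol, is kept. For the measured compounds named here, as no step between two measured compounds is available, there is no measured anchor for the size of this change. With every neighbour stopping at a limit, the expectation is that compound 4 will again show no effect within the tested range, or at most a shift that does not exceed the usual scatter, so the estimated step of an at least 1.2-fold lower number from compound 2 to compound 4 (0.07 log units; that floor lies within the scatter) is small. Compound 4 is therefore expected to give about 500 mg/kg, with a range from 150 mg/kg to 1500 mg/kg.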

Compound 4, dose for half-maximal effect: > 300 mg/kg
Compound 4 gave a limit, no number; the forecaster's own chance of this, stated with the estimate: 75%; the middle value lies beyond the limit too.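

Compound 2 and compound 4 both stopped at a limit in this assay, and no step can be read between them for chloro in place of methoxy. The compounds shown leave open whether any of them reaches a true dose for half-maximal effect in this assay, and whether this exchange changes that dose at all.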